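This account rests on a few compounds, and the source may have more. Where it says the series, first, only, none or still open, it means among the compounds named here.

In a functional assay on NCI-H929 cells (Homo sapiens) for cytotoxicity, read by fluorescence and resazurin assay, with a stated time of 72 h (a higher number here means a weaker inhibitor, a lower number a stronger inhibitor), compound 1 (`Nc1nc(Nc2ccc(S(N)(=O)=O)cc2)sc1C(=O)c1ccccc1[N+](=O)[O-]`) gives 1600 nM and compound 2 (`Nc1nc(Nc2ccc(S(N)(=O)=O)cc2)sc1C(=O)c1cccc(F)c1`) gives 1000 nM. Among the measured compounds shown here, these two values lie within the scatter of each other, so compound 2 stands level with the only other measured compound. Compound 3 (`Nc1cccc(C(=O)c2sc(Nc3ccc(S(N)(=O)=O)cc3)nc2N)c1`) has not yet been measured. It differs from compound 2 by amino in place of fluoro on an aromatic carbon, meta to a large group: amino in place of fluoro on an aromatic carbon. The same change reads as 3-fluorophenyl to 3-aminophenyl. For the measured compounds named here, the only measured step that bears on it is a 1.6-fold lower number from compound 1 to compound 2 (0.20 log units; within the scatter), which also concerns the phenyl group on a carbonyl carbon. Going by the values given here, no measured step brings in an amino group, so the data give no direction for this change, and one small step is thin evidence. On that basis, no step beyond the scatter is expected in this assay. The estimated change is a 1.1-fold lower number from compound 2 to compound 3 (0.05 log units; within the scatter). For compound 3 the estimated value is 900 nM, with an expected range of 300 nM to 2800 nM.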

Compound 3, half-maximal inhibitory concentration: 6800 nM
Compound 3: middle estimate off by 7.6-fold (0.88 log units), on the low side; the whole stated range lies below it.
By their numbers in this assay, from the lowest: compounds 2 and 1 (each within the scatter of the next); then compound 3.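

In this assay, among the compounds shown here, amino in place of fluoro on an aromatic carbon, meta to a large group, gives a 6.8-fold higher number from compound 2 to compound 3 (0.83 log units; beyond the scatter) and is the first step that lies beyond the scatter. This position is therefore not indifferent to its group, and the 3-aminophenyl group also separates from the 2-nitrophenyl group with a 4.3-fold higher number from compound 1 to compound 3 (0.63 log units; beyond the scatter) even though 3-fluorophenyl and 2-nitrophenyl stood within the scatter of each other. The phenyl group on the carbonyl carbon thus admits changes with no readable effect as well as one with a clear effect, but nothing available on these compounds accounts for the size or direction of this step.

Still open, on these data alone, is whether this step is specific to the amino group or would also appear with other groups on the same carbon, such as a hydroxyl, a methoxy or an acetamide. The compounds shown also leave open whether an unsubstituted phenyl would stand with the 3-fluorophenyl compound or with the 3-aminophenyl compound, so the step cannot yet be assigned to gaining amino or to losing fluoro.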